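The compounds below may be only part of what the source reports. "The series", "measured", "known", "first", "only" and "open" are said of these compounds alone.

Measured compounds:
Compound 1, `O=c1nc(NO)cc[nH]1`. In a functional assay on SW-620 cells (Homo sapiens) for inhibition, read by MTT assay, with a stated time of 72 h (a higher number here means a weaker inhibitor, a lower number a stronger inhibitor), compound 1 gives only a limit, > 100000 nM.
Compound 2, `Cc1cc(=O)[nH]c(=O)n1COC(CO)CO`. In this assay compound 2 gives only a limit, > 100000 nM.

Compound 1 stands at the limit of > 100000 nM in this assay, at which 2 of the 2 values shown sit; no number is known for it, only that it is not a stronger inhibitor than this limit allows. Compound 2 sits at the same limit, so the two values show nothing that separates one from the other, and neither gives a foothold for judging how any structural change moves potency.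

Compound 3, `CSc1cc[nH]c(=O)n1`, is not yet measured. It differs from compound 1 by methylsulfanyl in place of hydroxyamino on an aromatic carbon. Among the measured compounds shown here, no step between two measured compounds is available, so nothing measured tells how this exchange changes inhibition. Because compound 1 sits at the limit of > 100000 nM in this assay, at which 2 of the 2 values shown sit, the step in this assay is expected to be a number no higher from compound 1 to compound 3 (the limit leaves the size open), that is, nothing beyond the usual scatter of repeated measurements. Compound 3 is therefore expected to give about 100000 nM, within 30000 nM to 300000 nM, and most likely to be reported again as a limit rather than as a number.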

Compound 3, half-maximal inhibitory concentration: > 100000 nM
Compound 3 ended at the assay's limit; the forecaster's own chance of this, stated with the estimate: 85%; the middle value lies on the limit itself.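

In this assay compound 3 gives > 100000 nM as a limit and not a number. Among the compounds shown here, compound 1 also gives only a limit, so no step from compound 1 to compound 3 can be read: the limit of > 100000 nM in this assay, at which 3 of the 3 values shown sit.
The compounds shown leave open whether any change to these structures moves inhibition at all, and in which direction.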